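The source may report more compounds than this note shows. Statements on the series, on what has been measured and on what is new or still open speak of the compounds shown alone.

Compound 1 `Cn1cc(-c2cnc3[nH]cc(-c4ccc(C#N)cc4)c3c2)cn1` and compound 2 `Cn1cc(-c2cnc3[nH]cc(-c4ccc(C(N)=O)cc4)c3c2)cn1` share one core and differ only in the group carried on the aromatic ring. In a physicochemical assay for solubility, read by LC-MS, in phosphate buffer, measured as thermodynamic solubility, with a stated time of 24 h, at pH 7.4 (a lower number here means a less soluble compound, a higher number a more soluble compound), compound 1 gives 2000 nM, and compound 2 gives 3000 nM. Among the compounds with values here, the only measured step, a 1.5-fold higher number from compound 1 to compound 2 (0.18 log units; within the scatter), exchanged one group on that aromatic carbon for another and stayed within the scatter. Of the two numbers shown, compound 2 holds the larger one, but its nearest neighbour is compound 1 and the gap between them is within the scatter, so no order can be read from them.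

Compound 3 `Cn1cc(-c2cnc3[nH]cc(-c4ccc(C(=O)O)cc4)c3c2)cn1` differs from compound 2 by hydroxy in place of amino on a carbonyl carbon. Within the data shown here, no measured step bears on this exchange; the one step at hand, a 1.5-fold higher number from compound 1 to compound 2 (0.18 log units; within the scatter), concerns a different pair of groups and was too small to set a direction. What is expected therefore rests on the structural change alone, and on the fact that the two measured numbers sit close together. Compound 3 is expected to give 30000 nM, within 6000 nM to 150000 nM, and the expected step of a 10-fold higher number from compound 2 to compound 3 (1.00 log units; beyond the scatter) is an estimate, not a measurement.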

Compound 3, solubility: 850000 nM
Compound 3: middle estimate off by 28-fold (1.45 log units), on the low side, and the stated range ends below it.
By their numbers in this assay, from the lowest: compounds 1 and 2 (each within the scatter of the next); then compound 3.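

In this assay, the group on this aromatic carbon turns out to be able to shift the number far more than the first pair suggested: hydroxy in place of amino on a carbonyl carbon gives a 280-fold higher number from compound 2 to compound 3 (2.45 log units; beyond the scatter). The size of this step stands out further, as the computed counts for amino and hydroxy match in heavy atoms, hydrogen-bond donors and hydrogen-bond acceptors, so those counts do not track the difference seen here. Carboxy in place of cyano on an aromatic carbon gives a 430-fold higher number from compound 1 to compound 3 (2.63 log units; beyond the scatter), so carboxy stands apart from the other two groups shown at this place, while cyano and carbamoyl remain within the scatter of each other.

On these data alone, it remains open whether a similar shift would come with a different group on this aromatic carbon, such as a methyl ester, a sulfonamide or an amine, or with the carboxylic acid carried on a longer chain. No measurement at hand explains why this one exchange produces so large a step.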